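This account rests on a few compounds, and the source may have more. Where it says the series, first, only, none or still open, it means among the compounds named here.

Two compounds share one core, shown in compound 1 `CC(=O)Nc1ccc(NC(=O)c2cc(Cl)ccc2O)c(Cl)c1` and compound 2 `O=C(Nc1ccc(NCc2ccccc2)cc1Cl)c1cc(Cl)ccc1O`. In an ADME assay on A549 cells (Homo sapiens) for cytotoxicity, read by resazurin assay, with a stated time of 48 h (a higher number here means that more compound is tolerated, a lower number that less compound is tolerated), compound 1 gives "not determined" (no result reported), that is, no reported result. In this assay, among the measured compounds shown here, compound 2 gives 19700 nM, and this is the only number available, so compound 2 stands alone as the point of reference. Compound 3 `O=C(Nc1ccc(NCc2ccncc2)cc1Cl)c1cc(Cl)ccc1O` differs from compound 2 in a single place: pyridin-4-yl in place of phenyl on a saturated chain carbon bound to a nitrogen on an aromatic ring. For the measured compounds named here, no step between two measured compounds exists here to show how such a swap has moved the numbers. Going by the values given here, because the only anchor is compound 2 with 19700 nM and the change is one ring for another of the same size, the step of a 1.3-fold higher number from compound 2 to compound 3 (0.12 log units; within the scatter) is expected to be small, leaning toward a somewhat higher value but hardly beyond the scatter. Compound 3 is therefore estimated at 26000 nM, with a likely range from 11000 nM to 60000 nM.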

Compound 3, half-maximal cytotoxic concentration: 65300 nM
Compound 3: the middle estimate sits 2.5-fold (0.40 log units) below what was measured; measured number outside the range, above it.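

In this assay, putting pyridin-4-yl in place of phenyl on a saturated chain carbon bound to a nitrogen on an aromatic ring gives a 3.3-fold higher number from compound 2 to compound 3 (0.52 log units; beyond the scatter), so this position responds to a swap between two rings of equal heavy-atom count. The entering ring differs only by a nitrogen in the ring and the hydrogen-bond acceptor counted with it, and that small edit is enough to take the step beyond the usual scatter. Nothing shown here explains the rise.

This single pair cannot say whether the ring nitrogen's location matters, as pyridin-3-yl or pyridin-2-yl could show. It also leaves open whether a longer chain carrying the ring, such as 2-phenylethyl, or a saturated ring such as piperidin-4-yl, would shift the number in the same direction.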